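The compounds below may be only part of what the source reports. "The series", "measured", "known", "first", "only" and "open" are said of these compounds alone.

The measured compounds:
Compound 1, `O[C@@H](c1ccccc1)[C@H]1CO[C@H](c2ccccc2)[C@@H](C/C=C/c2cccc(F)c2)C1`: 8380 nM
Compound 2, `COc1ccc(/C=C/C[C@H]2C[C@@H]([C@@H](O)c3ccc(OC)c(OC)c3)CO[C@@H]2c2ccccc2)cc1OC`: 17000 nM
Compound 3, `COc1cccc(/C=C/C[C@@H]2C[C@@H]([C@@H](O)c3ccc(OC)c(OC)c3)CO[C@H]2c2ccc(OC)c(OC)c2)c1`: 16400 nM

All three were tested in a functional assay on HeLa cells (Homo sapiens) for cytotoxicity, read by WST assay, with a stated time of 48 h; on this read-out higher numbers stand for weaker inhibition and lower numbers for stronger inhibition. For the measured compounds named here, compound 1 sits at the low end of the three numbers; the gap to compound 3 is within the usual scatter, so those two cannot be told apart, while compound 2 lies beyond the scatter and is the only one clearly separated from compound 1.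

Compound 4, `O=[N+]([O-])c1ccc(/C=C/C[C@H]2C[C@@H]([C@@H](O)c3ccccc3)CO[C@@H]2c2ccccc2)cc1`, has not yet been measured in this assay. It shares the core of compound 1 and differs from it in a single place: 4-nitrophenyl in place of 3-fluorophenyl on a double-bonded chain carbon bound to a double-bonded chain carbon. Going by the values given here, no pair of measured compounds differs in just one place, so there is no measured step from which to read how much such an exchange shifts the number. The most cautious expectation is a step of a 1.1-fold higher number from compound 1 to compound 4 (0.03 log units; within the scatter) that stays within the scatter, in either direction. Compound 4 is therefore expected to give 9000 nM in this assay, with a range from 3000 nM to 27000 nM.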

Compound 4, half-maximal inhibitory concentration: 12400 nM
The estimate for compound 4 lay 1.4-fold (0.14 log units) below the measured number, within the range that was stated.
By their numbers in this assay, from the lowest: compounds 1, 4, 3 and 2 (each within the scatter of the next, the first and the last beyond it).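

In this assay, for the compounds shown here, putting 4-nitrophenyl in place of 3-fluorophenyl on a double-bonded chain carbon bound to a double-bonded chain carbon gives a 1.5-fold higher number from compound 1 to compound 4 (0.17 log units; within the scatter), the first step here between compounds that differ in one place. The entering group brings hydrogen-bond acceptors and the leaving group has none, yet this single exchange gives no shift that can be separated from the usual variation between repeated measurements. Nothing available here bears on why the number moves so little.

From the compounds shown here alone, it remains open whether an amine or a carboxylic acid on this phenyl ring would move the number beyond the scatter. Going by these compounds, it is also open whether 4-nitrophenyl would behave the same way on the more heavily substituted compound 3.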